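A few compounds are considered here, and "the series" means these few. Any claim that something is new, unique, unknown or untested is made for them only; others in the source may bear on it.

Measured so far in a functional assay on EBC-1 cells (Homo sapiens) for antiproliferative activity, with a stated time of 72 h; a higher number here means a weaker inhibitor, a lower number a stronger inhibitor

Compound 1 `Cn1cc(-c2cc(C(F)(F)F)c3ncc(Cc4ccc5ncccc5c4)n3c2)cn1` gives "not determined" (no result reported)

Compound 2 `Cn1cc(-c2cn3c(Cc4ccc5ncccc5c4)cnc3cc2C(F)(F)F)cn1` gives "not determined" (no result reported)

Compound 3 `CN1CCN(C(=O)c2ccc(-c3cc(F)c4ncc(Cc5ccc6ncccc6c5)n4c3)cc2F)CC1` gives 869 nM

Compound 3 is the only one of these with a number, so it cannot yet be ranked against compound 1 or compound 2. Compound 4 `O=C(NCc1cc(F)cc(F)c1)c1ccc(-c2cc(F)c3ncc(Cc4ccc5ncccc5c4)n3c2)cc1F` keeps everything in compound 3 except one group (3,5-difluorobenzyl)amino in place of 4-methylpiperazin-1-yl on a carbonyl carbon and in words this puts (3,5-difluorobenzyl)amino in place of 4-methylpiperazin-1-yl on a carbonyl carbon. A non-aromatic ring leaves, and an aromatic ring of carbon only enters along with a hydrogen-bond donor. For the measured compounds named here, no pair of measured compounds shows what such a change does, so the data offer no direction. Going by the values given here, the sole anchor is compound 3 at 869 nM and the expectation therefore stays close to it. The estimated 1.2-fold lower number from compound 3 to compound 4 (0.09 log units; within the scatter) is expected to be no larger than the usual scatter, although a swap of this size could move either way. In this assay the estimate for compound 4 is 700 nM with an expected range of 150 nM to 3500 nM around it.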

Compound 4, half-maximal inhibitory concentration: 53.6 nM
For compound 4 the middle estimate is 13-fold (1.12 log units) above the measured one, outside the stated range (below it).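

In this assay, the group on the carbonyl carbon clearly matters: a 16-fold lower number from compound 3 to compound 4 (1.21 log units; beyond the scatter) comes with (3,5-difluorobenzyl)amino in place of 4-methylpiperazin-1-yl, while the rest of the molecule stays the same. For the compounds shown here, this is the first measured step, so the earlier compounds, with one number and two entries without a result, could not show that this position responds at all, or in which direction. No separate measurement bears on the reason for this drop, so it stands as a single observation.

The swap removes a non-aromatic ring and brings in both an aromatic ring of carbon only and a hydrogen-bond donor, and the compounds shown cannot say which of these carries the step. As far as these compounds go, it also remains open whether an unsubstituted benzylamino group or a short methylamino group on the same carbonyl carbon would give a similar number.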